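Swapping one aryl group for another on the shared core

A few compounds are considered here, and "the series" means these few. Any claim that something is new, unique, unknown or untested is made for them only; others in the source may bear on it.

Of the compounds shown here, three sharing one core have been measured in an assay on isolated protein for inhibition of aldehyde dehydrogenase 1A1 (Homo sapiens), read by spectrophotometry, tested at 10 uM; on this read-out lower numbers stand for less inhibition and higher numbers for more inhibition at the one concentration tested (going by the name of the read-out). Compound 1 `CC(C)Cn1c(CN2CCN(C(=O)C3CC3)CC2)nc2ccccc21` gives 13.1%. Compound 2 `CC(C)=CCn1c(CN2CCN(C(=O)C3CC3)CC2)nc2ccccc21` gives 74.3%. Compound 3 `COc1cccc(Cn2c(CN3CCN(C(=O)C4CC4)CC3)nc3ccccc32)c1` gives 44.4%, the second highest of the three numbers; compound 2 stands nearest, with a number 29.9 percentage points lower from compound 2 to compound 3 (beyond the scatter), and compound 1 furthest, with a number 31.3 percentage points higher from compound 1 to compound 3 (beyond the scatter). Compound 4 `O=C(C1CC1)N1CCN(Cc2nc3ccccc3n2Cc2ccc(C(F)(F)F)cc2)CC1` has not yet been measured. It differs from compound 3 in one place: 4-(trifluoromethyl)phenyl in place of 3-methoxyphenyl on a saturated chain carbon bound to an aromatic nitrogen. Going by the values given here, no measured step exchanges one six-membered aromatic ring of carbon only for another. The steps that touch this position all start from a non-aromatic group: a number 61.2 percentage points higher from compound 1 to compound 2 (beyond the scatter) and a number 31.3 percentage points higher from compound 1 to compound 3 (beyond the scatter) both replace isopropyl, and a number 29.9 percentage points lower from compound 2 to compound 3 (beyond the scatter) replaces 2-methylprop-1-en-1-yl. Nothing measured separates two aromatic groups at this position, so the expected step for compound 4 is one no larger than the scatter, in no firm direction, a number 0.6 percentage points higher from compound 3 to compound 4 (within the scatter). Compound 4 is therefore estimated to give about 45%, somewhere between 20% and 72%.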

Compound 4, a percentage reported as inhibition, at one concentration (the size of the read-out at that concentration, not a potency): 37%
Estimate against measurement, compound 4: 8 percentage points above, and the stated range covers the measured number.
By their numbers in this assay, from the lowest: compound 1; then compounds 4 and 3 (each within the scatter of the next); then compound 2.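

In this assay, going by these compounds alone, the step of a number 7.4 percentage points lower from compound 3 to compound 4 (within the scatter) is the first exchange at this position of one six-membered aromatic ring of carbon only for another, and it stays within the scatter even though a methoxy group gives way to a trifluoromethyl group. The second aromatic group also keeps the distance from the two non-aromatic groups seen with compound 3, with a number 37.3 percentage points lower from compound 2 to compound 4 (beyond the scatter) and a number 23.9 percentage points higher from compound 1 to compound 4 (beyond the scatter) both beyond the scatter. No available evidence accounts for these differences.

The compounds shown do not separate the identity of the ring substituent from its place, since 3-methoxyphenyl and 4-(trifluoromethyl)phenyl differ in both. As far as these compounds go, it also remains open how an unsubstituted phenyl, a pyridine ring or a longer chain would read at this position.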